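The source may report more compounds than this note shows. Statements on the series, on what has been measured and on what is new or still open speak of the compounds shown alone.

Compound 1, `CC(C(=O)NCc1ccc(C(F)(F)F)nc1Nc1ccccc1)c1ccc(NS(C)(=O)=O)c(F)c1`, gives 59.6 nM in a functional assay on CHO-K1 cells for antagonist activity at transient receptor potential cation channel subfamily V member 1 (Homo sapiens), read by FLIPR; on this read-out lower numbers stand for stronger inhibition and higher numbers for weaker inhibition.
Compound 2, `CC(C(=O)NCc1ccc(C(F)(F)F)nc1N1CCC(c2ccccc2)CC1)c1ccc(NS(C)(=O)=O)c(F)c1`, gives 0.6 nM in this assay.
Compound 3, `COC1CCN(c2nc(C(F)(F)F)ccc2CNC(=O)C(C)c2ccc(NS(C)(=O)=O)c(F)c2)CC1`, gives 2.4 nM in this assay.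

Among these three numbers compound 3 holds the second highest. Its nearest neighbour is compound 2, separated by a 4.0-fold higher number from compound 2 to compound 3 (0.60 log units; beyond the scatter), and its furthest is compound 1, separated by a 25-fold lower number from compound 1 to compound 3 (1.40 log units; beyond the scatter).

The next compound, compound 4, is `CC(C(=O)NCc1ccc(C(F)(F)F)nc1N1CCCCCC1)c1ccc(NS(C)(=O)=O)c(F)c1`. It differs from compound 3 in one place: azepan-1-yl in place of 4-methoxypiperidin-1-yl on an aromatic carbon. The saturated ring attached to the aromatic carbon thus grows by one member and loses its methoxy group.

Two measured steps speak to this position. Replacing anilino with a saturated nitrogen ring gave a 99-fold lower number from compound 1 to compound 2 (2.00 log units; beyond the scatter) and a 25-fold lower number from compound 1 to compound 3 (1.40 log units; beyond the scatter), both large. Swapping the group on that saturated ring gave only a 4.0-fold higher number from compound 2 to compound 3 (0.60 log units; beyond the scatter), a modest shift. Compound 4 keeps a saturated nitrogen ring at the same aromatic carbon, so the large gain seen in compounds 2 and 3 over compound 1 is expected to hold, while the loss of the methoxy group and the extra ring member are expected to change little in this assay.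

Compound 4 is therefore estimated at 2 nM, in the range 0.5 nM to 8 nM, meaning an expected step of a 1.2-fold lower number from compound 3 to compound 4 (0.08 log units; within the scatter).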

Compound 4, inhibition constant: 0.8 nM
The estimate for compound 4 lay 2.5-fold (0.40 log units) above the measured number, within the range that was stated.
By their numbers in this assay, from the lowest: compounds 2 and 4 (each within the scatter of the next); then compound 3; then compound 1.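

The unsubstituted azepan-1-yl ring matches the 4-phenylpiperidin-1-yl group in this assay, with a 1.3-fold higher number from compound 2 to compound 4 (0.12 log units; within the scatter), so a phenyl group on the saturated ring is not required for a number this low. Replacing 4-methoxypiperidin-1-yl with azepan-1-yl brings a 3.0-fold lower number from compound 3 to compound 4 (0.48 log units; beyond the scatter), a modest step, while replacing anilino with azepan-1-yl brings a 75-fold lower number from compound 1 to compound 4 (1.87 log units; beyond the scatter), so all three saturated nitrogen rings shown, six-membered and seven-membered alike, give much lower numbers than anilino at this position. Nothing available explains why any of these groups gives the number it does.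

The step from the methoxy-bearing ring to azepan-1-yl changes ring size and removes the methoxy group together, and a plain piperidin-1-yl group would help to separate the two changes. Also open, as far as these compounds go, is how this position responds to a smaller ring such as pyrrolidin-1-yl, or to a ring with a second hetero atom such as morpholin-4-yl or piperazin-1-yl.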